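Swapping Bromine for Methoxy on the Benzylamine Arm

The source may hold more compounds than are shown below. What is called first, only, known or untested is meant among the compounds shown, and "the series" means these compounds.

Among the measured compounds shown here, compound 2 `O=S(=O)(NCCCNCc1ccc(Br)cc1)c1cc(C(F)(F)F)cc(C(F)(F)F)c1` is the only compound here with a numerical result: in a functional assay on PANC-1 cells (Homo sapiens) for inhibition, read by MTT assay, with a stated time of 72 h (on this read-out lower numbers stand for stronger inhibition of growth and higher numbers for weaker inhibition of growth), compound 2 gives 2200 nM. Compound 1 `CN(CCCNS(=O)(=O)c1cc(C(F)(F)F)cc(C(F)(F)F)c1)Cc1ccccc1` reaches only a limit of the assay, > 50000 nM, in this assay. For the measured compounds named here, the one measured step, an at least 22-fold lower number from compound 1 to compound 2 (1.35 log units; beyond the scatter), rests on that limit of > 50000 nM in this assay, at which 1 of the 2 values shown sits, and so gives only a lower bound on its true size. Compound 3 `COc1cccc(CNCCCNS(=O)(=O)c2cc(C(F)(F)F)cc(C(F)(F)F)c2)c1` differs from compound 2 by 3-methoxyphenyl in place of 4-bromophenyl on a saturated chain carbon bound to an amine nitrogen. The measured step touches this same arm of the molecule but alters two things at once, so it bears only loosely on the present change, and neither measured compound carries a methoxy group. The expectation is therefore a step of modest size in this assay, more likely towards weaker inhibition of growth than towards stronger, a 1.8-fold higher number from compound 2 to compound 3 (0.26 log units; within the scatter). Compound 3 is estimated at 4000 nM, with a range from 1500 nM to 15000 nM.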

Compound 3, concentration for 50% growth inhibition: 10000 nM
The estimate for compound 3 lay 2.5-fold (0.40 log units) below the measured number; the range from low to high includes it.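

In this assay, replacing 4-bromophenyl with 3-methoxyphenyl gives a 4.5-fold higher number from compound 2 to compound 3 (0.66 log units; beyond the scatter). Unlike the earlier step, which altered two things at once, this one changes only the aromatic group on this arm, and it shows that this change alone moves the result beyond the usual scatter. The methoxy compound also compares favourably with the methylated benzylamine, with an at least 5.0-fold lower number from compound 1 to compound 3 (0.69 log units; beyond the scatter), but that step is only a lower bound and also alters more than one feature of the arm, and it rests on a limit of the assay: the limit of > 50000 nM in this assay, at which 1 of the 3 values shown sits.

The change swaps the group and also shifts its place on the ring, so the effects of these two differences cannot be separated here. Going by these compounds, a 4-methoxyphenyl or 3-bromophenyl group would pull them apart, and a 4-chlorophenyl group or a longer chain remains open as well.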